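The source may report more compounds than this note shows. Statements on the series, on what has been measured and on what is new or still open speak of the compounds shown alone.

Compound 1 `Clc1ccc(COc2ccccc2/C=C/C(/C=C/c2ccccn2)=N/Oc2ncnc3cc(Cl)ccc23)c(Cl)c1` gives 91.8% in a functional assay on SMMC-7721 cells (Homo sapiens) for inhibition, read by MTT assay, with a stated time of 72 h, tested at 10 uM; a higher number here means a stronger effect of the compound at the concentration tested, a lower number a weaker effect. Compound 2 `Fc1ccccc1COc1ccccc1/C=C/C(/C=C/c1ccccn1)=N/Oc1ncnc2cc(Cl)ccc12` gives 94.8% in this assay.

Compound 2 holds the higher of the two numbers, yet its step of a number 3 percentage points higher from compound 1 to compound 2 (within the scatter) lies within the scatter, so the two compounds cannot be ordered. Compound 3 `Clc1ccc2c(O/N=C(\C=C\c3ccccn3)/C=C/c3ccccc3OCc3ccccc3Cl)ncnc2c1` has not been measured. The change from compound 2 is chloro in place of fluoro on an aromatic carbon. Within the data shown here, the one measured step, a number 3 percentage points higher from compound 1 to compound 2 (within the scatter), also swaps halogens on this ring and is within the scatter, so no step beyond the scatter is expected. Compound 3 is estimated at 93%, between 82% and 98%, a step of a number 1.8 percentage points lower from compound 2 to compound 3 (within the scatter).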

Compound 3, a percentage reported as inhibition, at one concentration (the size of the read-out at that concentration, not a potency): 94.5%
For compound 3 the middle estimate is 1.5 percentage points below the measured one; low and high end bracket the measured number.
By their numbers in this assay, from the lowest: compounds 1, 3 and 2 (each within the scatter of the next).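

With chloro in place of fluoro at this place, ortho to a large group, this assay gives a number 0.3 percentage points lower from compound 2 to compound 3 (within the scatter), so these two halogens cannot be told apart here. Hydrogen in place of chloro on an aromatic carbon of the same ring gives a number 2.7 percentage points higher from compound 1 to compound 3 (within the scatter), so that change cannot be read as an effect either. Nothing measured on these compounds accounts for this.

Open, as far as these compounds go, is whether a methoxy group or an amine on this ring would give a step beyond the scatter. Also open, from the compounds shown here alone, is whether a longer chain in place of the benzyl carbon would do so.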